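Sulfonamide Nitrogen Substituents and Antiproliferative Potency

The source may report more compounds than this note shows. Statements on the series, on what has been measured and on what is new or still open speak of the compounds shown alone.

Three compounds share one core and differ only at a sulfonamide nitrogen. Compound 1 `NS(=O)(=O)c1ccc(N/C(S)=N\c2ccnc3cc(C(F)(F)F)ccc23)cc1` carries hydrogen there; in a functional assay on AS49-RAW cells (Homo sapiens) for antiproliferative activity, read by sulforhodamine B assay, with a stated time of 48 h (on this read-out higher numbers stand for weaker inhibition and lower numbers for stronger inhibition), compound 1 gives 36600 nM. Compound 2 `Cc1cc(NS(=O)(=O)c2ccc(N/C(S)=N\c3ccnc4cc(C(F)(F)F)ccc34)cc2)on1` gives 60200 nM, and compound 3 `O=S(=O)(Nc1ncccn1)c1ccc(N/C(S)=N\c2ccnc3cc(C(F)(F)F)ccc23)cc1` gives 37800 nM. Compound 3 thus sits second highest of the three numbers, nearest to compound 1 and furthest from compound 2, both gaps within the scatter. The three steps show how little this position has mattered so far: a 1.6-fold higher number from compound 1 to compound 2 (0.22 log units; within the scatter), a 1.0-fold higher number from compound 1 to compound 3 (0.01 log units; within the scatter) and a 1.6-fold lower number from compound 2 to compound 3 (0.20 log units; within the scatter). Compound 4 `COc1ncnc(NS(=O)(=O)c2ccc(N/C(S)=N\c3ccnc4cc(C(F)(F)F)ccc34)cc2)c1OC` is the next variation at the same place: 5,6-dimethoxypyrimidin-4-yl in place of pyrimidin-2-yl on a sulfonamide nitrogen. The two steps that bear on it, the swap from compound 1 to compound 3 and from compound 2 to compound 3, were both within the scatter, so no step beyond the scatter is expected in this assay; the estimated step is a 1.1-fold higher number from compound 3 to compound 4 (0.02 log units; within the scatter). Compound 4 is therefore estimated at 40000 nM, with a range from 18000 nM to 90000 nM.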

Compound 4, half-maximal inhibitory concentration: 81800 nM
For compound 4 the middle estimate is 2.0-fold (0.31 log units) below the measured one; the range from low to high includes it.
By their numbers in this assay, from the lowest: compounds 1, 3, 2 and 4 (each within the scatter of the next, the first and the last beyond it).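

In this assay this sulfonamide nitrogen now gives its first steps beyond the scatter, with a 2.2-fold higher number from compound 3 to compound 4 (0.34 log units; beyond the scatter) and a 2.2-fold higher number from compound 1 to compound 4 (0.35 log units; beyond the scatter), both modest. The position is therefore not wholly indifferent to what it carries, although the 5,6-dimethoxypyrimidin-4-yl group cannot be told apart from the 3-methyl-1,2-oxazol-5-yl group of compound 2, with a 1.4-fold higher number from compound 2 to compound 4 (0.13 log units; within the scatter). No measurement shown here accounts for the higher number that comes with the 5,6-dimethoxypyrimidin-4-yl group.

The compounds shown leave open whether this step follows the two methoxy groups or the pyrimidin-4-yl ring itself. They also leave open whether an acetyl or a methyl group on this nitrogen would move the number in either direction.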